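The compounds below may be only part of what the source reports. "The series", "measured", "known", "first", "only" and "open" are said of these compounds alone.

Values in a functional assay on HeLa cells (Homo sapiens) for antiproliferative activity, read by MTT assay, with a stated time of 48 h; a lower number here means a stronger inhibitor, a higher number a weaker inhibitor:
- compound 1 `COc1ccc(N(C)c2ccnc(Cl)n2)cc1[N+](=O)[O-]`: 4730 nM
- compound 2 `COc1ccc(N(C)c2cc(C)nc(C)n2)cc1Cl`: 316 nM

Of these two measurements, compound 2 at 316 nM holds the lower number, and the gap to compound 1 at 4730 nM lies beyond the scatter. The two compounds differ in more than one place, so their gap does not isolate any single change.

The next compound is compound 3 `COc1ccc(N(C)c2cc(C)nc(C)n2)cc1O`, which keeps the core of compound 2 and changes one substituent: hydroxy in place of chloro on an aromatic carbon. It has hydroxy in place of chloro on an aromatic carbon, ortho to a methoxy group and meta to a large group.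

Within the data shown here, no measured pair shows this exchange, so the expectation rests only on compound 2 at 316 nM and is loose. In this assay, no step beyond the scatter is expected, with a slight lean towards a weaker number. The estimated step is a 1.3-fold higher number from compound 2 to compound 3 (0.10 log units; within the scatter). For compound 3 the expected value is 400 nM, with an estimated range from 90 nM to 2500 nM.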

Compound 3, half-maximal inhibitory concentration: 93 nM
For compound 3 the middle estimate is 4.3-fold (0.63 log units) above the measured one, within the range that was stated.
By their numbers in this assay, from the lowest: compound 3; then compound 2; then compound 1.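

In this assay, among these compounds, hydroxy in place of chloro on the aromatic carbon ortho to a methoxy group and meta to a large group gives a 3.4-fold lower number from compound 2 to compound 3 (0.53 log units; beyond the scatter) and provides the only single-place comparison so far. This position is therefore not indifferent to its substituent: with the rest of compound 2 held fixed, the lower number goes with hydroxy, which counts one hydrogen-bond donor and one hydrogen-bond acceptor, and the higher number with chloro, which counts neither. No measurement at hand accounts for the size or the direction of this step.

One pair cannot separate what hydroxy adds from what the departure of chloro removes, and an amine or a carboxylic acid on the same carbon would give further points for telling these apart. On these data alone, it also remains open whether the same exchange would move the number in the same direction on the core of compound 1, which differs from compound 2 in more than one place.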